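This account rests on a few compounds, and the source may have more. Where it says the series, first, only, none or still open, it means among the compounds named here.

Measured in an ADME assay on L1210/0 cells (Mus musculus) for cytotoxicity, with a stated time of 48 h; a higher number here means a weaker inhibitor, a lower number a stronger inhibitor:
- compound 1 `O=c1[nH]c(=O)n([C@H]2C[C@H](O)[C@@H](CO)O2)cc1/C=N/O`: 15500 nM
- compound 2 `O=c1[nH]c(=O)n([C@H]2C[C@H](O)[C@@H](CO)O2)cc1/C=C/I`: 63900 nM
- compound 3 `C=Cc1cn([C@H]2C[C@H](O)[C@@H](CO)O2)c(=O)[nH]c1=O`: 14200 nM

Compound 3 stands at 14200 nM. The step of a 1.1-fold lower number from compound 1 to compound 3 (0.04 log units; within the scatter) shows no real separation between these two neighbours, whereas the step of a 4.5-fold lower number from compound 2 to compound 3 (0.65 log units; beyond the scatter) sets it apart from the analogue carrying 2-iodoethenyl.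

The change now in view puts azidomethyl in place of vinyl on an aromatic carbon, giving compound 4 `[N-]=[N+]=NCc1cn([C@H]2C[C@H](O)[C@@H](CO)O2)c(=O)[nH]c1=O`: azidomethyl in place of vinyl on an aromatic carbon. For the measured compounds named here, no measured compound carries azidomethyl, so the evidence is indirect. It comes from the three steps at this same place on the shared core: the two above and the step of a 4.1-fold higher number from compound 1 to compound 2 (0.62 log units; beyond the scatter). These are small to modest, and three compounds give no direction for a new group. A step beyond the scatter is therefore not specifically expected, although a modest move either way would not surprise.

For compound 4, the estimated step is a 1.2-fold higher number from compound 3 to compound 4 (0.08 log units; within the scatter). The expected value for compound 4 is 17000 nM, with an estimated range of 3500 nM to 70000 nM.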

Compound 4, half-maximal inhibitory concentration: 124000 nM
The estimate for compound 4 lay 7.3-fold (0.86 log units) below the measured number, outside the stated range (above it).
By their numbers in this assay, from the lowest: compounds 3 and 1 (each within the scatter of the next); then compounds 2 and 4 (each within the scatter of the next).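

In this assay, for the compounds shown here, azidomethyl at this position brings an 8.7-fold higher number from compound 3 to compound 4 (0.94 log units; beyond the scatter) and also an 8.0-fold higher number from compound 1 to compound 4 (0.90 log units; beyond the scatter) so a new group here can move the number further than any step among the earlier compounds did. Against 2-iodoethenyl the change gives only a 1.9-fold higher number from compound 2 to compound 4 (0.29 log units; within the scatter) so two quite different groups read alike, and the four compounds now fall into two pairs: compounds 3 and 1 at the lower numbers, compounds 2 and 4 at the higher. Nothing available here accounts for this split between the pairs.

The compounds shown leave open whether the higher number follows the azide end of azidomethyl or its methylene link to the core. An aminomethyl group, a hydroxymethyl group or a longer carbon chain at this place would help to separate the two.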